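A Fluorine Added to the Phenyl Ring of Compound 3

The source may hold more compounds than are shown below. What is called first, only, known or untested is meant among the compounds shown, and "the series" means these compounds.

Three compounds were measured in an ADME assay on the whole organism (Rattus norvegicus, strain Sprague-Dawley) for metabolic stability; on this read-out lower numbers stand for a shorter-lived compound and higher numbers for a longer-lived compound. Compound 1 `NC(=O)c1cc(-c2ccccc2)cc2c(C3CCN(S(=O)(=O)CCCN4CCCC4)CC3)c[nH]c12` gives 4.6 h, compound 2 `CC1(C)C[C@H](c2c[nH]c3c(C(N)=O)cc(-c4ccc(F)cc4)cc23)CCS1(=O)=O` gives 4.5 h, and compound 3 `NC(=O)c1cc(-c2ccccc2)cc2c(C3CCS(=O)(=O)CC3)c[nH]c12` gives 1.58 h, the lowest of the three numbers, with a gap to each of the others that lies beyond the scatter. Compound 4 `NC(=O)c1cc(-c2ccc(F)cc2)cc2c(C3CCS(=O)(=O)CC3)c[nH]c12` differs from compound 3 in one place: fluoro in place of hydrogen on an aromatic carbon. Within the data shown here, no measured pair in this set shows this change on its own, so its effect in this assay is not known from the data. Compound 2 also carries the 4-fluorophenyl but differs from compound 3 elsewhere too, so its value is a comparison, not a step. A small rise is expected, the step of a 1.6-fold higher number from compound 3 to compound 4 (0.20 log units; within the scatter) likely within or only slightly beyond the scatter. For compound 4 the estimate is 2.5 h, in the range 1.3 h to 5 h.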

Compound 4, half-life: 2.2 h
Beside the measured number, compound 4's estimate is 1.1-fold (0.06 log units) above it; low and high end bracket the measured number.
By their numbers in this assay, from the lowest: compounds 3 and 4 (each within the scatter of the next); then compounds 2 and 1 (each within the scatter of the next).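

In this assay, among these compounds, fluoro in place of hydrogen on the phenyl ring gives a 1.4-fold higher number from compound 3 to compound 4 (0.14 log units; within the scatter), the first direct reading of this change in the set. This place on the aromatic ring therefore takes a fluoro group with no step beyond the scatter, and compound 3 and compound 4 cannot be told apart on half-life. Nothing at hand gives a cause for this result. As far as these compounds go, what remains open is how chloro, methoxy, trifluoromethyl or a nitrile would read in the same place, and whether an amine there would give a step beyond the scatter.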